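Ester chain variants of a shared core: microsomal stability

The source may report more compounds than this note shows. Statements on the series, on what has been measured and on what is new or still open speak of the compounds shown alone.

Measured compounds:
- compound 1, `CCCCOC(=O)Cc1c(C(C)C)nc(CCCC)n(Cc2ccc(-c3ccccc3-c3noc(=O)[nH]3)cc2)c1=O`: 7.1%
- compound 2, `CCCCCOC(=O)Cc1c(C(C)C)nc(CCCC)n(Cc2ccc(-c3ccccc3-c3noc(=O)[nH]3)cc2)c1=O`: 10.6%
- compound 3, `CCCCc1nc(C(C)C)c(CC(=O)OC(CC)CC)c(=O)n1Cc1ccc(-c2ccccc2-c2noc(=O)[nH]2)cc1`: 7.7%

All three numbers come from an ADME assay on microsomes from liver (Homo sapiens) for metabolic stability, with a stated time of 30 min; a higher number here means that more of the compound is left, a lower number that less of the compound is left. Compound 2 does not stand apart from the others in this assay: the step of a number 3.5 percentage points higher from compound 1 to compound 2 (within the scatter) and the step of a number 2.9 percentage points lower from compound 2 to compound 3 (within the scatter) both lie within the scatter, as does the step of a number 0.6 percentage points higher from compound 1 to compound 3 (within the scatter). The three measured compounds therefore form one group with no gap between them beyond the scatter.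

Compound 4, `CC#CCOC(=O)Cc1c(C(C)C)nc(CCCC)n(Cc2ccc(-c3ccccc3-c3noc(=O)[nH]3)cc2)c1=O`, is not yet measured. Compared with compound 2 the change is prop-1-yn-1-yl in place of butyl on a saturated chain carbon bound to an oxygen next to a carbonyl group; cut one bond further out, the same difference reads pentyl to but-2-yn-1-yl on the ester oxygen.

Among the measured compounds shown here, the steps that bear on this change are the ester-chain variations already measured: a number 3.5 percentage points higher from compound 1 to compound 2 (within the scatter), a number 0.6 percentage points higher from compound 1 to compound 3 (within the scatter) and a number 2.9 percentage points lower from compound 2 to compound 3 (within the scatter), all within the scatter. On that basis no step beyond the scatter is expected for compound 4 either, so the expected step is a number 1.6 percentage points lower from compound 2 to compound 4 (within the scatter). The number for compound 4 in this assay is estimated at 9%, with a range from 3% to 18%.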

Compound 4, percent of the compound remaining: 13.7%
Estimate against measurement, compound 4: 4.7 percentage points below, within the range that was stated.
By their numbers in this assay, from the lowest: compounds 1, 3, 2 and 4 (each within the scatter of the next).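

The ester oxygen now carries a chain with a triple bond, and in this assay the change from pentyl to but-2-yn-1-yl gives a number 3.1 percentage points higher from compound 2 to compound 4 (within the scatter) and so does not set compound 4 apart from the saturated chain of compound 2. Compound 4 also stays in the same group when read against the branched pentan-3-yl, with a number 6 percentage points higher from compound 3 to compound 4 (within the scatter) as the step, and against the straight butyl chain, with a number 6.6 percentage points higher from compound 1 to compound 4 (within the scatter) as the step; these two are the largest steps in the set so far, yet both remain inside the scatter, so a triple bond in the chain, with one heavy atom fewer than pentyl, adds a third kind of ester chain to the straight and branched ones without opening a gap. No measurement in hand explains the numbers of these esters.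

The compounds shown leave open whether any change at this position can lift the percent remaining beyond the scatter, since all four esters form a single group. A carboxylic acid or an amide in place of the ester, or a cyclohexyl ring on the ester oxygen, would test this more sharply than another chain of similar length.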